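The source may hold more compounds than are shown below. What is called first, only, known or untested is meant among the compounds shown, and "the series" means these compounds.

Compound 1 `CCCCCCn1cnc2c(Nc3ccc(O)cc3)nc(N[C@H]3CC[C@H](N)CC3)nc21` gives 3500 nM in a functional assay on MCF7 cells (Homo sapiens) for inhibition, read by fluorescence, with a stated time of 72 h (a lower number here means a stronger inhibitor of growth, a higher number a weaker inhibitor of growth), and it stands at the low end of the two numbers recorded. Compound 2 `CC(C)CCn1cnc2c(Nc3ccccc3)nc(N[C@H]3CC[C@H](N)CC3)nc21` gives 5400 nM in this assay, a value within the scatter of compound 1, so no order between the two can be claimed. Compound 3 `CCCCCCn1cnc2c(Nc3cccc(Cl)c3)nc(N[C@H]3CC[C@H](N)CC3)nc21` has not yet been measured. It differs from compound 1 in one place: 3-chlorophenyl in place of 4-hydroxyphenyl on a nitrogen on an aromatic ring. For the measured compounds named here, no step between measured compounds covers this change, and compound 2, which differs from compound 1 in more than one place, does not separate from it beyond the scatter. On that basis the step of a 1.2-fold lower number from compound 1 to compound 3 (0.07 log units; within the scatter) is expected to be small, with no direction beyond the scatter. Compound 3 is estimated at 3000 nM in this assay, with a range from 1000 nM to 9000 nM.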

Compound 3, concentration for 50% growth inhibition: 2700 nM
Compound 3: the middle estimate sits 1.1-fold (0.05 log units) above what was measured; low and high end bracket the measured number.
By their numbers in this assay, from the lowest: compounds 3, 1 and 2 (each within the scatter of the next).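

In this assay, 3-chlorophenyl in place of 4-hydroxyphenyl on a nitrogen on an aromatic ring gives a 1.3-fold lower number from compound 1 to compound 3 (0.11 log units; within the scatter) and so sets no order between the two compounds. For the compounds shown here, this is the first comparison at this position that differs in one place only. It shows that a group with 0 hydrogen-bond donors and 0 hydrogen-bond acceptors can stand in for one with 1 of each, at the same count of 7 heavy atoms, without the number leaving the scatter. Nothing measured here bears on why this is so. The hydroxyl and the chlorine change together in this step, and the compounds shown do not separate one from the other. From the compounds shown here alone, whether an aminophenyl, a carboxyphenyl or a methoxyphenyl group at this nitrogen would move the number beyond the scatter also stays open.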